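Pyridin-4-yl on the Cyclopropane: Compound 4 Estimated

The source may report more compounds than this note shows. Statements on the series, on what has been measured and on what is new or still open speak of the compounds shown alone.

Compound 1 `CC[C@H](C)[C@H](N)CN(C(=O)[C@@H]1C[C@H]1c1cccc(Cl)c1)c1ccc(-c2ccccc2)cc1`: 2200 nM
Compound 2 `CC[C@H](C)[C@H](N)CN(C(=O)[C@@H]1C[C@H]1C1CCCCC1)c1ccc(-c2ccccc2)cc1`: > 25000 nM
Compound 3 `CC[C@H](C)[C@H](N)CN(C(=O)[C@@H]1C[C@H]1c1ccc(F)cc1F)c1ccc(-c2ccccc2)cc1`: 1300 nM

In a functional assay for agonist activity at G protein-coupled receptor 88 (Homo sapiens), read by HTRF and cAMP accumulation (on this read-out higher numbers stand for an effect only at larger amounts of compound and lower numbers for an effect already at smaller amounts), compound 3 gives 1300 nM, the lowest of the two numbers reported; compound 1 sits at 2200 nM, and the pair is a 1.7-fold lower number from compound 1 to compound 3 (0.23 log units; within the scatter). For compound 2 the assay gives only a limit, > 25000 nM (the limit of > 25000 nM in this assay, at which 1 of the 3 values shown sits).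

Compound 4 `CC[C@H](C)[C@H](N)CN(C(=O)[C@@H]1C[C@H]1c1ccncc1)c1ccc(-c2ccccc2)cc1` differs from compound 3 in one place: pyridin-4-yl in place of 2,4-difluorophenyl on a saturated ring carbon. Within the data shown here, two measured steps bear on this. Replacing the aryl group with cyclohexyl gave an at least 11-fold higher number from compound 1 to compound 2 (1.05 log units; beyond the scatter), and going the other way gave an at least 19-fold lower number from compound 2 to compound 3 (1.28 log units; beyond the scatter); swapping one substituted phenyl for another gave only a 1.7-fold lower number from compound 1 to compound 3 (0.23 log units; within the scatter). Among the measured compounds shown here, compound 4 keeps a six-membered aromatic ring, so a loss as large as with cyclohexyl is not expected, but the exchange of a carbon-only ring for one with a hetero atom has no measured precedent here, and a moderate rise in the number is expected: a 3.1-fold higher number from compound 3 to compound 4 (0.49 log units; beyond the scatter). For compound 4 the estimate is 4000 nM, between 1500 nM and 15000 nM.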

Compound 4, half-maximal effective concentration: 1500 nM
Beside the measured number, compound 4's estimate is 2.7-fold (0.43 log units) above it; the measured number falls inside the stated range.
By their numbers in this assay, from the lowest: compounds 3, 4 and 1 (each within the scatter of the next). At a limit, above all of these: compound 2.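

In this assay, a ring with a hetero atom is accepted on this saturated ring carbon: pyridin-4-yl in place of 2,4-difluorophenyl gives a 1.2-fold higher number from compound 3 to compound 4 (0.06 log units; within the scatter), and pyridin-4-yl in place of 3-chlorophenyl gives a 1.5-fold lower number from compound 1 to compound 4 (0.17 log units; within the scatter), so among these compounds neither a halogen nor a carbon-only aromatic ring is required. Pyridin-4-yl in place of cyclohexyl gives an at least 16-fold lower number from compound 2 to compound 4 (1.22 log units; beyond the scatter), which extends the gap between the saturated ring and the aromatic rings to one with a hetero atom. That step starts from a limit and not a number, the one held by compound 2: the limit of > 25000 nM in this assay, at which 1 of the 4 values shown sits.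

The compounds shown leave open whether the place of the ring nitrogen matters, as pyridin-3-yl or pyridin-2-yl would show. They also leave open whether piperidin-4-yl, a saturated ring with a nitrogen, would behave like cyclohexyl or like the aromatic rings.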